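The source may hold more compounds than are shown below. What is called first, only, known or untested is meant among the compounds shown, and "the series" means these compounds.

Measured so far in a functional assay on cells (Cancer cell lines, Homo sapiens) for inhibition; a higher number here means a weaker inhibitor of growth, a lower number a stronger inhibitor of growth:

- compound 1 `Cc1cn2c(/C=N/NC(=N)N)c(-c3ccsc3)nc2s1` gives 11000 nM in this test
- compound 2 `N=C(N)N/N=C/c1c(-c2ccsc2)nc2sccn12` gives 15500 nM in this test

Within the data shown here, only one step has been measured, a 1.4-fold higher number from compound 1 to compound 2 (0.15 log units; within the scatter), and it lies within the scatter. Among the measured compounds shown here, compound 2 therefore cannot be told apart from compound 1, the only other compound with a number.

Compound 3 `N=C(N)N/N=C/c1c(-c2cccs2)nc2sccn12` has the same atoms as compound 2, joined differently: thiophen-2-yl in place of thiophen-3-yl on an aromatic carbon. The sulfur-containing ring stays, but it is attached through a different ring carbon. For the measured compounds named here, the one measured step bears on this only indirectly, since it swaps methyl for hydrogen at another place and leaves the thiophene untouched. Going by the values given here, no measured compound carries thiophen-2-yl, so the data hold no direct guide to this change. With so little evidence, no shift beyond the scatter is expected in this assay for this swap. The expected step is a 1.1-fold lower number from compound 2 to compound 3 (0.04 log units; within the scatter), which is too small to read as a real difference. The estimated value for compound 3 is 14000 nM, with an expected range from 6000 nM to 32000 nM.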

Compound 3, concentration for 50% growth inhibition: 10200 nM
Compound 3: middle estimate off by 1.4-fold (0.14 log units), on the high side, within the range that was stated.
By their numbers in this assay, from the lowest: compounds 3, 1 and 2 (each within the scatter of the next).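

Swapping thiophen-3-yl for thiophen-2-yl, on an aromatic carbon of a five-membered aromatic ring with 2 nitrogen, gives in this assay a 1.5-fold lower number from compound 2 to compound 3 (0.18 log units; within the scatter), and this is the first direct reading at this position. The step lies within the scatter, so compound 2 and compound 3 cannot be told apart, and the ring carbon through which the thiophene is attached makes no difference that this test can resolve. No measured property of either group is available to bear on this result.

The reading covers only one kind of change, since the sulfur-containing ring is kept and merely attached differently, and all the compounds shown carry a thiophene at this position. On these data alone, whether this position depends on a thiophene at all remains open, as does what a phenyl ring, a methyl group or an amine in its place would do to the number in this assay, where a larger difference might or might not appear.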